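The source may report more compounds than this note shows. Statements on the series, on what has been measured and on what is new or still open speak of the compounds shown alone.

Measured compounds:
- compound 1 `COc1ccc(OC)c(-c2cc(-c3ccccc3)nn2-c2ccc(S(N)(=O)=O)cc2)c1`, in a functional assay on cells (Cancer cell lines, Homo sapiens) for cytotoxicity, read by sulforhodamine B assay, with a stated time of 48 h (a lower number here means a stronger inhibitor of growth, a higher number a weaker inhibitor of growth), compound 1 gives 28800 nM
- compound 2 `Oc1ccc(O)c(-c2cc(-c3ccccc3)nn2-c2ccccc2)c1`, in this assay compound 2 gives 100000 nM

Compound 2 holds the highest of the two numbers in this assay; its nearest neighbour is compound 1, whose number is lower by a margin beyond the scatter. The two differ in more than one place, so their values cannot be read as a single step.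

Compound 3 `NS(=O)(=O)c1ccc(-n2nc(-c3ccccc3)cc2-c2cc(O)ccc2O)cc1` is the next compound for this assay. Relative to compound 2 the change is sulfamoyl in place of hydrogen on an aromatic carbon. Going by the values given here, no measured pair isolates this change. Among the compounds with values here, the only guide is compound 1, which carries the sulfamoyl group and gives 28800 nM, a lower number than compound 2, though compound 1 also differs at the two oxygen substituents, so the contribution of the sulfamoyl group alone is unknown.

The expectation is a modest move toward a lower number, as a 2.0-fold lower number from compound 2 to compound 3 (0.30 log units; within the scatter), not far beyond the scatter. Compound 3 is estimated at 50000 nM, with a range from 18000 nM to 100000 nM.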

Compound 3, concentration for total growth inhibition: 100000 nM
The estimate for compound 3 lay 2.0-fold (0.30 log units) below the measured number, and the stated range covers the measured number.
By their numbers in this assay, from the lowest: compound 1; then compounds 2 and 3 (each within the scatter of the next).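

In this assay, sulfamoyl in place of hydrogen on an aromatic carbon, para to a large group, gives no change at the digits printed from compound 2 to compound 3 (within the scatter) and thus, with the 2,5-dihydroxyphenyl group held constant, does not by itself reproduce the lower number of compound 1. Going by these compounds alone, with sulfamoyl held constant, 2,5-dihydroxyphenyl in place of 2,5-dimethoxyphenyl gives a 3.5-fold higher number from compound 1 to compound 3 (0.54 log units; beyond the scatter) and so places the only step beyond the scatter in this small set at the oxygen substituents, not at the sulfamoyl position. No measurement available here explains either step.

Whether sulfamoyl has any effect on the 2,5-dimethoxyphenyl background remains open, since the compounds shown contain no pair isolating that change. Also open, on these data alone, is how a carboxylic acid or an amine at the sulfamoyl position, or a longer alkoxy chain in place of methoxy, would read in this assay on this core.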